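This account rests on a few compounds, and the source may have more. Where it says the series, first, only, none or still open, it means among the compounds named here.

Measured so far in an ADME assay for permeability, using PAMPA, with a stated time of 4 h, tested at 10 uM; a higher number here means that the compound crosses the layer faster, a lower number that the compound crosses the layer more slowly:
- Compound 1 `O=C(CCCCN1CCCCC1)Nc1cc(-c2ccco2)n[nH]1`: > 10 10^-6 cm/s (a limit)
- Compound 2 `O=C(CCCCN1CCCCC1)Nc1cc(-c2ccncc2)n[nH]1`: 2 10^-6 cm/s
- Compound 3 `COc1cccc(-c2cc(NC(=O)CCCCN3CCCCC3)[nH]n2)c1`: > 10 10^-6 cm/s (a limit)

Compound 3 stands at > 10 10^-6 cm/s, which is a limit and not a number. Its place is the limit of > 10 10^-6 cm/s in this assay, at which 2 of the 3 values shown sit.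

Compound 4 `O=C(CCCCN1CCCCC1)Nc1cc(-c2ccc(Br)cc2)n[nH]1` carries 4-bromophenyl in place of 3-methoxyphenyl on an aromatic carbon.

The clearest measured steps are an at least 5.0-fold lower number from compound 1 to compound 2 (0.69 log units; beyond the scatter) and an at least 5.0-fold higher number from compound 2 to compound 3 (0.69 log units; beyond the scatter). Both involve the pyridin-4-yl group of compound 2, which compound 4 does not carry. The remaining step, a step that the two limits leave unreadable from compound 1 to compound 3, gives no size.

In this assay, no step beyond the scatter is therefore expected, and the estimated step is a step that the limit leaves unreadable from compound 3 to compound 4. Compound 4 is expected at 12 10^-6 cm/s, within an estimated range from 6 10^-6 cm/s to 25 10^-6 cm/s.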

Compound 4, apparent permeability: > 10 10^-6 cm/s
Compound 4: a limit, no number; the forecaster's own chance of this, stated with the estimate: 65%; the middle value lies beyond the limit too.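

Replacing pyridin-4-yl with 4-bromophenyl gives an at least 5.0-fold higher number from compound 2 to compound 4 (0.69 log units; beyond the scatter), so a second six-membered aromatic ring of carbon only, with a different substituent, also stands clear of compound 2 in this assay. The steps from compound 1 and compound 3 to compound 4 cannot be read. Compound 4 gives a limit, not a number, and adds to those already seen: the limit of > 10 10^-6 cm/s in this assay, at which 3 of the 4 values shown sit.

From the compounds shown here alone, how far compound 1, compound 3 and compound 4 lie apart stays open. So does whether a phenyl ring carrying an amine or a carboxylic acid would sit at this limit or nearer compound 2.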